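Swapping Bromo for Methoxy on a Tetrabrominated Core

The source may hold more compounds than are shown below. What is called first, only, known or untested is meant among the compounds shown, and "the series" means these compounds.

Compound 3 `OC(CCn1nc2c(Br)c(Br)c(Br)c(Br)c2n1)c1cccc(Br)c1` gives 118% in a functional assay on CCRF-CEM cells (Homo sapiens) for antiproliferative activity, read by MTT assay, with a stated time of 48 h, tested at 12.5 uM (on this read-out higher numbers stand for a weaker effect at the one concentration tested and lower numbers for a stronger effect), the highest of the three numbers shown, with compound 2 `OC(CCn1nc2c(Br)c(Br)c(Br)c(Br)c2n1)c1ccc(Cl)cc1` at 93% and compound 1 `OC(CCn1nc2c(Br)c(Br)c(Br)c(Br)c2n1)c1cccc(Cl)c1` at 70%; its steps to both lie beyond the scatter, so compound 3 shows the weakest effect of the three. Compound 4 `COc1cccc(C(O)CCn2nc3c(Br)c(Br)c(Br)c(Br)c3n2)c1` differs from compound 3 by methoxy in place of bromo on an aromatic carbon. Within the data shown here, no measured step exchanges a halogen for methoxy. The step bearing on this same position is a number 48 percentage points higher from compound 1 to compound 3 (beyond the scatter), which shows that the group there can move the number a great deal. A sizeable step in this assay is therefore expected, its direction uncertain, and is estimated as a number 28 percentage points lower from compound 3 to compound 4 (beyond the scatter). Compound 4 is estimated at 90%, within 55% to 125%.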

Compound 4, a percentage reported as activity, at one concentration (the size of the read-out at that concentration, not a potency): 96%
The estimate for compound 4 lay 6 percentage points below the measured number, and the stated range covers the measured number.
By their numbers in this assay, from the lowest: compound 1; then compounds 2 and 4 (each within the scatter of the next); then compound 3.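

Methoxy in place of bromo on this aromatic carbon strengthens the effect, giving a number 22 percentage points lower from compound 3 to compound 4 (beyond the scatter), but methoxy in place of chloro weakens it, giving a number 26 percentage points higher from compound 1 to compound 4 (beyond the scatter), so the three groups at this place span a clear order, with chloro strongest, then methoxy, then bromo. The 3-methoxyphenyl and 4-chlorophenyl groups cannot be told apart, with a number 3 percentage points higher from compound 2 to compound 4 (within the scatter). No measurement at hand explains these differences. From the compounds shown here alone, what an amine or a carboxylic acid would do at this place on the ring remains open.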